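The source may hold more compounds than are shown below. What is called first, only, known or untested is meant among the compounds shown, and "the series" means these compounds.

Measured in an ADME assay on HeLa cells (Homo sapiens) for cytotoxicity, read by MTT assay, with a stated time of 2 days; on this read-out lower numbers stand for higher toxicity in this test and higher numbers for lower toxicity in this test:
compound 1 `CCOC(=O)c1sc2cc(Oc3ccnc(C(=O)NC)c3)ccc2c1C`: > 100000 nM (a limit)
compound 2 `CCOC(=O)c1sc2cc(Oc3ccnc(C(=O)NC)c3)ccc2c1CC`: 16700 nM
compound 3 `CNC(=O)c1cc(Oc2ccc3c(C)c(C(=O)OC)sc3c2)ccn1`: 15700 nM

Compound 1 gives no number, only (the limit of > 100000 nM in this assay, at which 1 of the 3 values shown sits). The step to follow turns compound 1 into compound 4 `CCOC(=O)c1sc2cc(Oc3ccnc(C(=O)OC)c3)ccc2c1C`. The change is methoxy in place of methylamino on a carbonyl carbon, or methylcarbamoyl to methoxycarbonyl when cut one bond further out.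

Two measured steps start from compound 1, each a small change at another place in the molecule. They are an at least 5.9-fold lower number from compound 1 to compound 2 (0.77 log units; beyond the scatter) and an at least 6.3-fold lower number from compound 1 to compound 3 (0.80 log units; beyond the scatter). Neither touches the methylcarbamoyl group, so they offer no direct measure of this swap. They do show that in this assay small edits to compound 1 brought the read-out down from the limit to a real number, both times beyond the scatter. A step in the same direction is therefore expected here, of about that size or somewhat smaller, and compound 4 may also stay at the limit.

The expected change, an estimate resting on those two steps alone, is an at least 2.5-fold lower number from compound 1 to compound 4 (0.39 log units; beyond the scatter). For compound 4 the estimated value is 40000 nM, with an expected range from 10000 nM to 100000 nM.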

Compound 4, half-maximal cytotoxic concentration: 26200 nM
For compound 4 the middle estimate is 1.5-fold (0.18 log units) above the measured one; the measured number falls inside the stated range.
By their numbers in this assay, from the lowest: compounds 3, 2 and 4 (each within the scatter of the next). At a limit, above all of these: compound 1.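

In this assay, putting methoxy in place of methylamino on the carbonyl carbon gives an at least 3.8-fold lower number from compound 1 to compound 4 (0.58 log units; beyond the scatter), so this end of the molecule also bears on the read-out, something the two earlier edits, both made elsewhere on compound 1, could not show. Methylamino counts one hydrogen-bond donor and methoxy one hydrogen-bond acceptor, but this single swap cannot tell whether that difference lies behind the step. The true size of the step remains open-ended because compound 1 gives a limit rather than a number: the limit of > 100000 nM in this assay, at which 1 of the 4 values shown sits.

What the compounds shown leave open is how other groups on this carbonyl carbon would read, such as the hydroxyl of a carboxylic acid, a dimethylamino group or a longer chain like ethoxy. Also open, on these data alone, is whether the same swap would give a similar step on compound 2 or compound 3, where both ends of the comparison could be real numbers instead of a limit at one end.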